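Hydroxy to amino on two cores of a dioxygenase inhibitor series

The source may hold more compounds than are shown below. What is called first, only, known or untested is meant among the compounds shown, and "the series" means these compounds.

Compound 1 `Cn1cncc1-c1cc(Cl)ccc1O` carries a hydroxy group on its carbon ring. In an assay on cells for inhibition of Indoleamine 2,3-dioxygenase 1 (Homo sapiens), read by HPLC, with a stated time of 20 min (a higher number here means a weaker inhibitor, a lower number a stronger inhibitor), compound 1 gives 17000 nM. Compound 2 `Cn1cncc1-c1cc(Cl)ccc1N` is the same molecule with the change (amino in place of hydroxy on an aromatic carbon), and in this assay compound 2 gives 1200000 nM. That change produced a 71-fold higher number from compound 1 to compound 2 (1.85 log units; beyond the scatter).

Compound 3 `Oc1ccc(Cl)cc1-c1nnn[nH]1` rests on a different core; how the two cores differ is not broken down here. In this assay compound 3 gives 16000 nM, which sits within the usual scatter of the number for compound 1. Compound 4 `Nc1ccc(Cl)cc1-c1nnn[nH]1` is still to be measured. Within the data shown here, it differs from compound 3 by amino in place of hydroxy on an aromatic carbon, which is the same kind of change as the one from compound 1 to compound 2, though here the hydroxy stands ortho to a group of 5 heavy atoms rather than 6.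

The account expects compound 4 to move by a 50-fold higher number from compound 3 to compound 4 (1.70 log units; beyond the scatter), an estimate resting on the step of a 71-fold higher number from compound 1 to compound 2 (1.85 log units; beyond the scatter) seen on the other core. Compound 4 is therefore estimated at 800000 nM, with a range from 150000 nM to 3000000 nM to allow for the difference between the two cores.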

Compound 4, half-maximal inhibitory concentration: 220 nM
The estimate for compound 4 lay 3600-fold (3.56 log units) above the measured number, and the stated range ends above it.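

In this assay, amino in place of hydroxy on an aromatic carbon gave a 73-fold lower number from compound 3 to compound 4 (1.86 log units; beyond the scatter), and set beside the earlier step the same change ran in opposite directions on the two cores: the same change on two cores in this assay, a 71-fold higher number (1.85 log units; beyond the scatter) from compound 1 to compound 2 and a 73-fold lower number (1.86 log units; beyond the scatter) from compound 3 to compound 4, 5100-fold (3.71 log units) apart, beyond the scatter of two such steps This shows that, for these two pairs, the direction of the change on one core did not predict its direction on the other, so a step seen on the core of compound 1 cannot simply be carried over to the core of compound 3. Among these compounds, it does not show which feature of the cores lies behind the reversal or how the change would behave on any further core, since each core contributes only one pair.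

Going by these compounds, it remains open whether a methoxy group or a methylamino group in the same place would follow hydroxy or amino on either core. Also open, on these data alone, is whether the reversal would persist with a fluoro or a methyl group in place of the chloro group.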